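Thiourea series: aryl for tert-butyl on the chain nitrogen

The compounds below may be only part of what the source reports. "The series", "measured", "known", "first", "only" and "open" are said of these compounds alone.

Two members of the series carry a measurement. Compound 1 `O=c1ccc(-c2ccccc2)nn1CCCCNC(=S)Nc1ccc(Cl)cc1` was tested in a functional assay on the whole organism with Rattus norvegicus as the target, at a dose of 100 mg/kg (a lower number here means less inhibition, a higher number more inhibition at the dose given (going by the name of the read-out)), and gives 43.2%. Compound 2 `CC(C)(C)/N=C(\S)NCCCCn1nc(-c2ccccc2)ccc1=O` gives in this assay a value of 33.6%. The two numbers lie within the scatter of each other, so compound 2 and compound 1 cannot be told apart on this read-out; compound 2 simply sits at one end of the span the two measured numbers define.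

Compound 3 `O=c1ccc(-c2ccccc2)nn1CCCCNC(=S)Nc1ccccc1` has not yet been measured in this assay. Relative to compound 2 the change is a group of 9 heavy atoms (7 carbon, 1 nitrogen, 1 sulfur; one six-membered aromatic ring of carbon only) in place of a group of 7 heavy atoms (5 carbon, 1 nitrogen, 1 sulfur; no ring), on an amine nitrogen. Going by the values given here, no step between measured compounds is available to calibrate a change of this kind, so the expectation rests only on the two measured values.

The estimate for compound 3 in this assay is 40%, with a range from 25% to 55%. This expected step, a number 6.4 percentage points higher from compound 2 to compound 3 (within the scatter), is small and lies within the scatter, with compound 3 expected to fall inside the span set by compound 2 and compound 1.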

Compound 3, a percentage reported as inhibition, in the whole organism at one dose (the size of the read-out at that dose, not a potency): 38.4%
The estimate for compound 3 lay 1.6 percentage points above the measured number; the measured number falls inside the stated range.
By their numbers in this assay, from the lowest: compounds 2, 3 and 1 (each within the scatter of the next).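

In this assay, placing a group with one six-membered aromatic ring of carbon only on the amine nitrogen, in place of the group with no ring, gives a number 4.8 percentage points higher from compound 2 to compound 3 (within the scatter) and so does not separate the two groups on this read-out. The second step, hydrogen in place of chloro on an aromatic carbon, gives a number 4.8 percentage points lower from compound 1 to compound 3 (within the scatter) and adds a comparison the earlier pair could not give: chloro and hydrogen at this aromatic carbon also cannot be told apart here. Nothing on hand offers an explanation for these numbers.

From the compounds shown here alone, it remains open whether a carboxylic acid or an amine in place of the chloro, or a longer chain in place of the butyl chain, would give a step beyond the scatter. Because the read-out comes from a single dose, it also leaves open how these compounds would compare at other doses or in terms of potency.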